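Fluorine on the outer ring of compound 2: expectation

This account rests on a few compounds, and the source may have more. Where it says the series, first, only, none or still open, it means among the compounds named here.

Of the compounds shown here, three sharing one core have been tested in an assay on isolated protein for inhibition of methionine--tRNA ligase, cytoplasmic (Homo sapiens); a lower number here means a stronger inhibitor, a higher number a weaker inhibitor. Compound 1 `NC(=O)c1cc(-c2ccc(-c3ccc(Cl)cc3Cl)cc2)n(-c2ccccn2)n1` reaches only the limit of the assay, giving > 100000 nM. Compound 3 `O=C(O)c1cc(-c2ccc(-c3ccc(Cl)cc3Cl)cc2)n(-c2ccccn2)n1` likewise stops at the limit, at > 100000 nM. Among the measured compounds shown here, the one step between measured compounds, hydroxy in place of amino on a carbonyl carbon, is therefore not readable: a step that the two limits leave unreadable from compound 1 to compound 3. For the measured compounds named here, compound 2 `O=C(O)c1cc(-c2ccc(-c3ccccc3)cc2)n(-c2ccc(Cl)cc2Cl)n1` stands alone as the only compound with a number, giving 44300 nM in this assay. The other two results sit at the limit of > 100000 nM in this assay, at which 2 of the 3 values shown sit.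

Compound 4 `O=C(O)c1cc(-c2ccc(-c3ccc(F)cc3)cc2)n(-c2ccc(Cl)cc2Cl)n1` differs from compound 2 in one place: fluoro in place of hydrogen on an aromatic carbon. Going by the values given here, no measured step bears on this change; the single recorded step concerns a different part of the molecule and its size is unknown. With nothing in the data pointing in either direction, the expectation for the change of fluoro in place of hydrogen on an aromatic carbon is a step no larger than the usual scatter, in no particular direction. Compound 4 is accordingly estimated to give about 40000 nM in this assay, within a range of 15000 nM to 100000 nM. The step this estimate implies is expected to be a 1.1-fold lower number from compound 2 to compound 4 (0.04 log units; within the scatter).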

Compound 4, half-maximal inhibitory concentration: 41300 nM
For compound 4 the middle estimate is 1.0-fold (0.01 log units) below the measured one; measured number inside the range.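

Among the compounds shown here, replacing phenyl with 4-fluorophenyl gives the first step whose size can be read in this assay: it is a 1.1-fold lower number from compound 2 to compound 4 (0.03 log units; within the scatter), whereas the only earlier step, on the carbonyl carbon, cannot be read, with both of its compounds standing at a limit of the assay. At this place, para to a large group on a six-membered aromatic ring of carbon only, hydrogen and fluoro therefore cannot be told apart in this assay, and compound 4 remains a measurable compound, as compound 2 is. Nothing recorded here gives a reason for this outcome.

It remains open whether a larger group at the same place, such as chloro, methoxy or trifluoromethyl, or an amine would separate from hydrogen by more than the scatter, since a single fluoro is the only replacement shown there. Also open, as far as these compounds go, is what a methyl ester or a tetrazole in place of the carboxylic acid would do on the core of compound 2, where a change at that end has yet to give a readable step.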